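The source may report more compounds than this note shows. Statements on the series, on what has been measured and on what is new or still open speak of the compounds shown alone.

compound 1 `COc1ccccc1-c1csc2cnc(Nc3ccc(NC(=O)[C@@H]4CCCNC4)cc3)nc12` gives 410 nM
compound 2 `COc1ccccc1-c1csc2cnc(Nc3ccc(C(=O)NC4CCNCC4)cc3C)nc12` gives 3240 nM
compound 3 `COc1ccccc1-c1csc2cnc(Nc3cc(F)c(C(=O)NC4CCNCC4)cc3F)nc12` gives 2570 nM

For the measured compounds named here, these numbers come from a functional assay on MDA-MB-231 cells (Homo sapiens) for inhibition, read by MTT assay, with a stated time of 72 h (on this read-out lower numbers stand for stronger inhibition and higher numbers for weaker inhibition), and no two of the compounds differ in one place only. Compound 2 at 3240 nM lies within the usual scatter of compound 3 at 2570 nM. Compound 1 at 410 nM stands clearly apart from both on this read-out, with a lower number than either.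

Compound 4 `COc1ccccc1-c1csc2cnc(Nc3ccc(C(=O)NC4CCNCC4)cc3)nc12` is compound 2 with one change hydrogen in place of methyl on an aromatic carbon. Going by the values given here, no measured pair shows this change alone. Compound 3 also carries the (piperidin-4-yl)carbamoyl group and gives 2570 nM so only a small move toward a lower number, near the edge of the scatter, is expected. The expected size is a 1.8-fold lower number from compound 2 to compound 4 (0.26 log units; within the scatter) in this assay. The estimate for compound 4 is 1800 nM with an expected range from 600 nM to 4500 nM.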

Compound 4, half-maximal inhibitory concentration: 110 nM
Compound 4: the middle estimate sits 16-fold (1.21 log units) above what was measured; measured number outside the range, below it.
By their numbers in this assay, from the lowest: compound 4; then compound 1; then compounds 3 and 2 (each within the scatter of the next).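

In this assay, hydrogen in place of methyl on an aromatic carbon, ortho to a large group, gives a 29-fold lower number from compound 2 to compound 4 (1.47 log units; beyond the scatter), so a single carbon at this position matters greatly. Placing (piperidin-4-yl)carbamoyl instead of ((piperidin-3-yl)carbonyl)amino on the ring gives a modest 3.7-fold lower number from compound 1 to compound 4 (0.57 log units; beyond the scatter). Nothing measured here accounts for either step. On these data alone, it remains open whether a chlorine atom or an amine on this carbon would behave more like methyl or like hydrogen. As far as these compounds go, whether methyl has the same effect alongside ((piperidin-3-yl)carbonyl)amino also remains open.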